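The source may report more compounds than this note shows. Statements on the series, on what has been measured and on what is new or still open speak of the compounds shown alone.

Compound 1 `CS(=O)(=O)c1cccc(-c2c[nH]c3c(=O)n(Cc4cc(F)ccc4C#N)c(N4CCC[C@@H](N)C4)nc23)c1` carries a 3-(methylsulfonyl)phenyl group on the shared core. In an ADME assay on microsomes from liver (Homo sapiens) for metabolic stability, read by LC-MS, tested at 1 mM (a lower number here means that the compound disappears faster, a higher number that the compound lasts longer), compound 1 gives > 3.33 h, which is a limit of the assay rather than a measured number. Compound 2 `CS(=O)(=O)c1ccccc1-c1c[nH]c2c(=O)n(Cc3cc(F)ccc3C#N)c(N3CCC[C@@H](N)C3)nc12` differs only in that group. In this assay compound 2 gives > 3.33 h, again a limit. For the measured compounds named here, the one measured step, a step that the two limits leave unreadable from compound 1 to compound 2, therefore cannot be sized, and both values shown sit at the limit of > 3.33 h in this assay, at which 2 of the 2 values shown sit.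

Compound 3 `CS(=O)(=O)c1ccc(-c2c[nH]c3c(=O)n(Cc4cc(F)ccc4C#N)c(N4CCC[C@@H](N)C4)nc23)c(F)c1` has not yet been measured. It differs from compound 1 in one place: 2-fluoro-4-(methylsulfonyl)phenyl in place of 3-(methylsulfonyl)phenyl on an aromatic carbon

Going by the values given here, no measured step bears directly on this change, and the only comparable step is unreadable. On this basis compound 3 is expected to stay near the same limit, with an expected step that the limit leaves unreadable from compound 1 to compound 3. The estimate for compound 3 in this assay is 4.5 h, in a range from 2 h to 10 h.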

Compound 3, half-life: > 3.33 h
Compound 3: only a limit was reported; the forecaster's own chance of this, stated with the estimate: 70%; the middle value does not contradict the limit.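

Compound 3, like compound 1 and compound 2, gives only a limit, so neither the step from compound 1 to compound 3 nor the step from compound 2 to compound 3 can be read: the limit of > 3.33 h in this assay, at which 3 of the 3 values shown sit.

The compounds shown leave open how long each one actually lasts in this assay, and whether changing this group makes any difference.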